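Bromo in place of hydrogen on a benzylidene indanone

A few compounds are considered here, and "the series" means these few. Any claim that something is new, unique, unknown or untested is made for them only; others in the source may bear on it.

Compound 1, `COc1ccc(/C=C2\Cc3c(cc(OC)c(OC)c3OC)C2=O)cc1[N+](=O)[O-]`: 1560 nM
Compound 2, `COc1ccc(/C=C2\Cc3c(cc(OC)c(OC)c3OC)C2=O)cc1`: 750 nM
Compound 3, `COc1cc2c(c(OC)c1OC)C/C(=C\c1cc(OC)c(OC)c(OC)c1OC)C2=O`: a limit, > 10000 nM

The three compounds were tested in a functional assay on PC-3 cells (Homo sapiens) for antiproliferative activity, read by MTT assay, with a stated time of 48 h; on this read-out lower numbers stand for stronger inhibition of growth and higher numbers for weaker inhibition of growth. Compound 2 has the lowest of the two numbers reported; its nearest neighbour is compound 1, which sits higher. For compound 3 this assay gives only a limit, > 10000 nM, and no number; one of the three values shown sits at this limit (the limit of > 10000 nM in this assay, at which 1 of the 3 values shown sits).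

Among the measured compounds shown here, the only measured step between compounds differing in a single place is a 2.1-fold lower number from compound 1 to compound 2 (0.32 log units; beyond the scatter), a modest change, in which the nitro group of compound 1 is replaced by hydrogen. The new compound 4, `COc1ccc(/C=C2\Cc3c(cc(OC)c(OC)c3OC)C2=O)cc1Br`, differs from compound 2 by bromo in place of hydrogen on an aromatic carbon, so a bromine now occupies the carbon that carried the nitro group in compound 1.

This step bears on the new change only loosely, since bromo is not nitro. Because compound 1 with its nitro substituent gave 1560 nM, a substituent at this carbon is expected to raise the number at most modestly, or not beyond the scatter. Compound 4 is therefore expected to give 1100 nM, within 450 nM to 2700 nM, an expected step of a 1.5-fold higher number from compound 2 to compound 4 (0.17 log units; within the scatter).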

Compound 4, concentration for 50% growth inhibition: 389 nM
Compound 4: the middle estimate sits 2.8-fold (0.45 log units) above what was measured, and the stated range ends above it.
By their numbers in this assay, from the lowest: compounds 4 and 2 (each within the scatter of the next); then compound 1. At a limit, above all of these: compound 3.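

In this assay, the step of a 1.9-fold lower number from compound 2 to compound 4 (0.29 log units; within the scatter) shows that this aromatic carbon, ortho to a methoxy group, can carry a bromo group in place of hydrogen with no change that stands clear of the scatter. The earlier compounds shown here offered only the nitro group at this carbon, and the step of a 4.0-fold lower number from compound 1 to compound 4 (0.60 log units; beyond the scatter) now shows that the substituent's identity matters here, since the higher number of compound 1 goes with nitro and not with the mere presence of a substituent on this carbon. Nothing available here gives a reason for the difference between bromo and nitro at this carbon.

On these data alone, it remains open whether chloro, a methyl group, an amine or a carboxylic acid on this carbon would stay level with compound 2 and compound 4 or would give a number closer to that of compound 1. As far as these compounds go, it is also open whether bromo would be tolerated in the same way on the other aromatic carbons of this six-membered ring, or whether a larger group such as a longer alkoxy chain could take the place of the neighbouring methoxy group.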